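Swapping methoxy for methyl on an aromatic carbon

This account rests on a few compounds, and the source may have more. Where it says the series, first, only, none or still open, it means among the compounds named here.

Measured in a functional assay on DLD-1 cells (Homo sapiens) for cytotoxicity, with a stated time of 48 h; on this read-out lower numbers stand for stronger inhibition and higher numbers for weaker inhibition:
- compound 1 `C[S+]([O-])/C=C/c1cc(=O)c2ccccc2o1`: 8000 nM
- compound 2 `COc1ccc2c(=O)cc(/C=C/[S+](C)[O-])oc2c1`: 7800 nM
- compound 3 `COc1cccc2oc(/C=C/[S+](C)[O-])cc(=O)c12`: > 10000 nM

For compound 3 the result > 10000 nM is a limit of the assay and not a number.

The next compound, compound 4 `Cc1cccc2oc(/C=C/[S+](C)[O-])cc(=O)c12`, differs from compound 3 in one place: it carries methyl in place of methoxy on an aromatic carbon. Among the compounds with values here, two measured steps bear on this change, both of them placing methoxy in place of hydrogen on an aromatic carbon. One gave a 1.0-fold lower number from compound 1 to compound 2 (0.01 log units; within the scatter). The other, at the carbon that changes here, gave an at least 1.2-fold higher number from compound 1 to compound 3 (0.09 log units; that floor lies within the scatter). Neither shows a change beyond the scatter, although the second is only a floor. Removing the methoxy group is therefore not expected to produce a step beyond the scatter in this assay, and compound 4 should stay close to compound 1 at 8000 nM. The expected change is an at least 1.1-fold lower number from compound 3 to compound 4 (0.04 log units; that floor lies within the scatter). Compound 4 is estimated at 9000 nM, with an expected range from 4000 nM to 20000 nM.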

Compound 4, half-maximal inhibitory concentration: 5500 nM
Estimate against measurement, compound 4: 1.6-fold (0.21 log units) above; the measured number falls inside the stated range.
By their numbers in this assay, from the lowest: compounds 4, 2 and 1 (each within the scatter of the next). At a limit, above all of these: compound 3.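

In this assay, placing methyl on this aromatic carbon gives a 1.5-fold lower number from compound 1 to compound 4 (0.16 log units; within the scatter), so a small carbon group here cannot be told apart from hydrogen. Exchanging methoxy for methyl at the same carbon gives an at least 1.8-fold lower number from compound 3 to compound 4 (0.25 log units; that floor lies within the scatter), so even this floor does not separate the two groups. The result for compound 3 is a limit and not a number, which leaves the true size of that step unknown: the limit of > 10000 nM in this assay, at which 1 of the 4 values shown sits.

The compounds shown leave open whether a different kind of group on this carbon, such as an amine or a carboxylic acid, would move the number beyond the scatter. As far as these compounds go, it is also open whether methyl on the carbon that carries methoxy in compound 2 would behave as it does here.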